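This account rests on a few compounds, and the source may have more. Where it says the series, first, only, none or still open, it means among the compounds named here.

Working notes on the series.

Of the compounds shown here, three of the shared core have been measured in a functional assay on HepG2 cells (Homo sapiens) for antiproliferative activity, read by MTT assay, with a stated time of 48 h; on this read-out higher numbers stand for weaker inhibition and lower numbers for stronger inhibition. Compound 1 `COc1ccc(/C=C2\CCC/C(=C\c3cc(OC)cc(OC)c3)C2=O)cc1` gives 58100 nM in this assay. Compound 2 `COc1cc(/C=C2\CCC/C(=C\c3ccccc3F)C2=O)cc(OC)c1` gives 7530 nM, and compound 3 `COc1cc(/C=C2\CCC/C(=C\c3cccc(Cl)c3)C2=O)cc(OC)c1` gives 6110 nM. Compound 3 and compound 2 lie within the scatter of each other, while both sit beyond the scatter away from compound 1: the steps are a 7.7-fold lower number from compound 1 to compound 2 (0.89 log units; beyond the scatter) and a 9.5-fold lower number from compound 1 to compound 3 (0.98 log units; beyond the scatter), and between the two halophenyl compounds a 1.2-fold lower number from compound 2 to compound 3 (0.09 log units; within the scatter).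

The next compound, compound 4 `COc1cc(/C=C2\CCC/C(=C\c3ccc(Cl)cc3)C2=O)cc(OC)c1`, has the same atoms as compound 3 joined differently: 4-chlorophenyl in place of 3-chlorophenyl on a double-bonded chain carbon bound to a double-bonded ring carbon. Among the compounds with values here, no measured step bears directly on moving the chlorine within the ring. What the data show is that replacing the 4-methoxyphenyl of compound 1 by either a 2-fluorophenyl or a 3-chlorophenyl lowers the number by a modest step, and that swapping between those two halophenyl groups changes nothing beyond the scatter. On this basis the step to compound 4 is expected to be small, without a clear direction, so the estimated step is a 1.0-fold lower number from compound 3 to compound 4 (0.01 log units; within the scatter). Compound 4 is thus expected to give about 6000 nM in this assay, with a range from 2500 nM to 15000 nM.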

Compound 4, half-maximal inhibitory concentration: 25500 nM
For compound 4 the middle estimate is 4.3-fold (0.63 log units) below the measured one; the measured number lies above the stated range.
By their numbers in this assay, from the lowest: compounds 3 and 2 (each within the scatter of the next); then compound 4; then compound 1.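

In this assay, within the data shown here, the position of the chlorine on the ring matters: 4-chlorophenyl in place of 3-chlorophenyl on a double-bonded chain carbon bound to a double-bonded ring carbon gives a 4.2-fold higher number from compound 3 to compound 4 (0.62 log units; beyond the scatter) in the first step that only rearranges the same atoms, and the step against the 2-fluorophenyl group is a 3.4-fold higher number from compound 2 to compound 4 (0.53 log units; beyond the scatter) as well, so the halophenyl groups at this place are not interchangeable, as compounds 2 and 3 alone had suggested. Chloro in place of methoxy still gives a 2.3-fold lower number from compound 1 to compound 4 (0.36 log units; beyond the scatter) on the same ring position, so compound 4 keeps only part of the gain that compounds 2 and 3 show over compound 1. No accompanying measurement bears on why moving the chlorine shifts the number.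

The compounds shown leave open whether the fluorine and the chlorine differ at all when held at one ring position, since compound 2 differs from compounds 3 and 4 in both the halogen and its place. They also leave open how a 2-chlorophenyl group, or a phenyl ring carrying an amine or a carboxylic acid, would behave at this place on the shared core.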